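Working notes on cytotoxicity, compound 1 to compound 3

A few compounds are considered here, and "the series" means these few. Any claim that something is new, unique, unknown or untested is made for them only; others in the source may bear on it.

Compound 1 `CCCCNC(=O)Nc1cc2nc(C3CCCCC3)[nH]c2cc1N(CC)CC` is the reference point of this series. In an ADME assay on Vero cells (Chlorocebus sabaeus) for cytotoxicity, read by resazurin assay, with a stated time of 3 days (a lower number here means a stronger inhibitor, a higher number a weaker inhibitor), compound 1 gives > 100 ug/mL, which is a limit of the assay and not a number. Going by the values given here, compound 2 `COc1ccc(C(=O)Nc2cc3nc(C4CCCCC4)[nH]c3cc2N2CCCC2)cc1` is the only other measured member. In this assay compound 2 gives > 100 ug/mL, again a limit rather than a number. Among the compounds with values here, both values sit at the limit of > 100 ug/mL in this assay, at which 2 of the 2 values shown sit, so compound 1 stands where every value shown stands, and no step between measured compounds can be read. Compound 3 `C=Cc1cccc(C(=O)Nc2cc3nc(C4CCCCC4)[nH]c3cc2N(CC)CC)c1` is not yet measured. It differs from compound 1 as follows: 3-vinylphenyl in place of butylamino on a carbonyl carbon. With every measured value at the limit, no step beyond the scatter is expected in this assay from this change. The expected step that the limit leaves unreadable from compound 1 to compound 3 is taken as essentially none, with compound 3 expected to remain at the limit. The estimate for compound 3 in this assay is 120 ug/mL, in a range from 50 ug/mL to 300 ug/mL.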

Compound 3, half-maximal inhibitory concentration: > 100 ug/mL
Compound 3: no number, only a limit (the forecaster's own chance of this, stated with the estimate: 75%); the middle value does not contradict the limit.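

Compound 3 gives > 100 ug/mL and this is a limit of the assay, not a number. Going by these compounds alone, no step from compound 1 to compound 3 can be read: the limit of > 100 ug/mL in this assay, at which 3 of the 3 values shown sit. The compounds shown leave open whether any change on the carbonyl carbon would give a measurable cytotoxicity value.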